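Adding a Bromo Group to Compound 2

The source may report more compounds than this note shows. Statements on the series, on what has been measured and on what is new or still open speak of the compounds shown alone.

compound 1 `COc1ccc(N(CCNC(C)=O)c2ccccc2)cc1`: 776 nM
compound 2 `CC(=O)NCCN(c1ccccc1)c1ccccc1`: 126 nM

Both numbers come from an assay on NIH3T3 cells for displacement of a labelled ligand from melatonin receptor type 1A (Homo sapiens); a higher number here means a weaker inhibitor, a lower number a stronger inhibitor. Within the data shown here, compound 2 stands at the lowest of the two numbers, and the only measured step leads to it: a 6.2-fold lower number from compound 1 to compound 2 (0.79 log units; beyond the scatter), obtained by putting hydrogen in place of methoxy on an aromatic carbon. Compound 3 `CC(=O)NCCN(c1ccccc1)c1cccc(Br)c1` differs from compound 2 by bromo in place of hydrogen on an aromatic carbon. Among the measured compounds shown here, no measured step involves a bromo group, and the one known step concerns a methoxy group that is removed, not a group added, so it gives no direction for this change beyond showing that a substituent on this ring can move the number. The expectation is therefore a number near that of compound 2, with a wide range. Compound 3 is estimated at 110 nM, between 30 nM and 400 nM, which is expected to mean a 1.1-fold lower number from compound 2 to compound 3 (0.06 log units; within the scatter).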

Compound 3, inhibition constant: 17 nM
Compound 3: the middle estimate sits 6.5-fold (0.81 log units) above what was measured, outside the stated range (below it).
By their numbers in this assay, from the lowest: compound 3; then compound 2; then compound 1.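

In this assay, a single bromo on an aromatic carbon, meta to a large group, gives a 7.4-fold lower number from compound 2 to compound 3 (0.87 log units; beyond the scatter), so a change of just one heavy atom at this place clearly moves the number. Among these compounds, the only earlier step took a methoxy group away; here a group is added and the number still falls, so a substituent on this ring does not always raise it. Nothing measured here explains why bromo has this effect.

The compounds shown leave open whether this drop is particular to bromo or would also appear with chloro, methyl or a nitrile at the same place. They also leave open whether a bromo group elsewhere on the ring would lower the number as well.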